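A Fluorophenyl Replaces Thiophene at the Chain End

The source may hold more compounds than are shown below. What is called first, only, known or untested is meant among the compounds shown, and "the series" means these compounds.

Compound 2 `C=C/C=C\[C@H](C)[C@H](OC(N)=O)[C@@H](C)[C@H](O)[C@@H](C)C/C(C)=C\[C@H](C)[C@@H](O)[C@@H](C)/C=C\CCc1ccsc1` carries a thiophen-3-yl group at the end of the chain. Within the data shown here, in a functional assay on MCF7 cells (Homo sapiens) for cytotoxicity (on this read-out higher numbers stand for weaker inhibition and lower numbers for stronger inhibition), compound 2 gives 4000 nM, the second highest of the three numbers measured so far. Compound 1 `C=C/C=C\[C@H](C)[C@H](OC(N)=O)[C@@H](C)[C@H](O)[C@@H](C)C/C(C)=C\[C@H](C)[C@@H](O)[C@@H](C)/C=C\CCc1cccc(O)c1`, which bears 3-hydroxyphenyl in the same place, gives 390 nM in this assay, and compound 3 `C=C/C=C\[C@H](C)[C@H](OC(N)=O)[C@@H](C)[C@H](O)[C@@H](C)C/C(C)=C\[C@H](C)[C@@H](O)[C@@H](C)/C=C\CCc1ccc(Oc2ccccc2)cc1`, with 4-phenoxyphenyl there, gives 10000 nM. Among the measured compounds shown here, the one measured step that bears on the next change is a 10-fold higher number from compound 1 to compound 2 (1.01 log units; beyond the scatter), a large move upward when the thiophene took the place of the hydroxyphenyl. Compound 4 `C=C/C=C\[C@H](C)[C@H](OC(N)=O)[C@@H](C)[C@H](O)[C@@H](C)C/C(C)=C\[C@H](C)[C@@H](O)[C@@H](C)/C=C\CCc1cccc(F)c1` differs from compound 2 as follows: 3-fluorophenyl in place of thiophen-3-yl on a saturated chain carbon, two bonds along the chain from a double-bonded chain carbon. This brings back a six-membered aromatic ring of carbon only, as in compound 1, but with fluorine where compound 1 has its hydroxy group, so the hydrogen-bond acceptor of the thiophene leaves and no donor enters. Because compound 1 gives 390 nM while compound 2 gives 4000 nM, the number for compound 4 is expected to land between the two. Compound 4 is therefore estimated at 1500 nM, with a range from 400 nM to 6000 nM. The expected step is a 2.7-fold lower number from compound 2 to compound 4 (0.43 log units; beyond the scatter), downward but smaller than a 10-fold higher number from compound 1 to compound 2 (1.01 log units; beyond the scatter).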

Compound 4, half-maximal inhibitory concentration: 500 nM
For compound 4 the middle estimate is 3.0-fold (0.48 log units) above the measured one, within the range that was stated.
By their numbers in this assay, from the lowest: compounds 1 and 4 (each within the scatter of the next); then compound 2; then compound 3.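

Compound 4 restores what compound 2 lost: in this assay the exchange of thiophen-3-yl for 3-fluorophenyl gives an 8.0-fold lower number from compound 2 to compound 4 (0.90 log units; beyond the scatter), a step beyond the scatter. The earlier step from compound 1 to compound 2 changed the ring and removed the hydroxy group together, so it could not show whether the hydroxy group was needed at this chain end. Compound 4 separates the two, since a 1.3-fold higher number from compound 1 to compound 4 (0.11 log units; within the scatter) is a step within the scatter, and at this aromatic carbon fluoro takes the place of hydroxy with no difference that can be read, which leaves the ring exchange as the change that carries the step from compound 2 to compound 4.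

No measurement shown here gives a reason for this behaviour at the chain end.

Open is whether the six-membered ring needs any group on it at all, since plain phenyl does not stand among these compounds. On these data alone, it is also open how an amine or a carboxylic acid in place of the fluorine, or a longer chain between the ring and the double bond, would compare with compound 1 and compound 4.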